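Chain extension in a sulfonamide series

The source may hold more compounds than are shown below. What is called first, only, known or untested is meant among the compounds shown, and "the series" means these compounds.

- compound 1 `CCCCN(Cc1cn([C@@H]2O[C@H](COC(C)=O)[C@@H](OC(C)=O)[C@H]2OC(C)=O)nn1)S(C)(=O)=O`: 225000 nM
- compound 2 `CCCCCCCCCCCCCCN(Cc1cn([C@@H]2O[C@H](COC(C)=O)[C@@H](OC(C)=O)[C@H]2OC(C)=O)nn1)S(C)(=O)=O`: 31000 nM
- compound 3 `CCCCCCCCCCCCCCCCN(Cc1cn([C@@H]2O[C@H](COC(C)=O)[C@@H](OC(C)=O)[C@H]2OC(C)=O)nn1)S(C)(=O)=O`: not yet measured

Going by the values given here, in a functional assay on MDA-MB-231 cells (Homo sapiens) for antiproliferative activity, read by XTT assay, with a stated time of 48 h (on this read-out higher numbers stand for weaker inhibition and lower numbers for stronger inhibition), compound 2 gives 31000 nM, the lower of the two numbers so far. Compound 3 differs from it by ethyl in place of hydrogen on a saturated chain carbon, ten or more bonds along the chain from a sulfonamide nitrogen. Among the compounds with values here, one measured step bears on this change: a 7.3-fold lower number from compound 1 to compound 2 (0.86 log units; beyond the scatter). That step added decyl to the chain, whereas ethyl enters here, so a much smaller shift in the same direction is expected, probably not beyond the scatter in this assay. The expected shift is a 1.2-fold lower number from compound 2 to compound 3 (0.09 log units; within the scatter). For compound 3 the estimated value is 25000 nM, with an expected range of 10000 nM to 65000 nM.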

Compound 3, half-maximal inhibitory concentration: 15000 nM
Compound 3: middle estimate off by 1.7-fold (0.22 log units), on the high side, within the range that was stated.
By their numbers in this assay, from the lowest: compound 3; then compound 2; then compound 1.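

In this assay, ethyl in place of hydrogen on a saturated chain carbon still gives a 2.1-fold lower number from compound 2 to compound 3 (0.32 log units; beyond the scatter), so a small addition remains detectable. Going by these compounds alone, with dodecyl in place of hydrogen the full span is a 15-fold lower number from compound 1 to compound 3 (1.18 log units; beyond the scatter), and no compound of the three breaks the order of lower numbers with longer chains. Nothing available explains this order. Still open, from the compounds shown here alone, is whether a longer chain continues the trend, and whether an amine or a carboxylic acid on the chain preserves it.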